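A Phenyl Swapped for 2-Methoxyethyl on the Shared Core

The source may report more compounds than this note shows. Statements on the series, on what has been measured and on what is new or still open speak of the compounds shown alone.

Values measured so far in a functional assay on RAW264.7 cells (Mus musculus) for inhibition, read by ELISA, with a stated time of 24 h (on this read-out higher numbers stand for an effect only at larger amounts of compound and lower numbers for an effect already at smaller amounts), are these:
- Compound 1 `CC/C=C\C[C@H]1C(=O)C=C[C@H]1CC(=O)OCCCC` gives 23000 nM
- Compound 2 `CC/C=C\C[C@H]1C(=O)C=C[C@H]1CC(=O)Oc1ccccc1` gives 33000 nM
- Compound 3 `CC/C=C\C[C@H]1C(=O)C=C[C@H]1CC(=O)Oc1ccccc1OC` gives 32000 nM

Compound 2 cannot be told apart from either of the other two compounds on these numbers, since both of its measured neighbours lie within the usual scatter of it. The next compound, compound 4 `CC/C=C\C[C@H]1C(=O)C=C[C@H]1CC(=O)OCCOC`, keeps the shared core and carries 2-methoxyethyl in place of phenyl on an oxygen next to a carbonyl group.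

Within the data shown here, two measured steps bear on this change. The closer one is a 1.4-fold higher number from compound 1 to compound 2 (0.16 log units; within the scatter). It changes the same place and links an open chain, butyl, with phenyl. The other is a 1.0-fold lower number from compound 2 to compound 3 (0.01 log units; within the scatter), which shows that adding methoxy to the aromatic ring left the number within the scatter. Among the measured compounds shown here, no measured compound yet carries 2-methoxyethyl, so this expectation rests on those two small steps alone. No step beyond the scatter is therefore expected in this assay, and the estimate is a 1.2-fold lower number from compound 2 to compound 4 (0.07 log units; within the scatter) in size and direction.

The estimated value for compound 4 is 28000 nM, with an expected range from 14000 nM to 55000 nM in this assay.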

Compound 4, half-maximal effective concentration: 27000 nM
Compound 4: the middle estimate sits 1.0-fold (0.02 log units) above what was measured; the range from low to high includes it.
By their numbers in this assay, from the lowest: compounds 1, 4, 3 and 2 (each within the scatter of the next).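

In this assay, among these compounds, the earlier compounds compared only butyl with phenyl and a phenyl with a methoxy-bearing ring, and compound 4 now tests a third kind of group on an oxygen next to a carbonyl group: 2-methoxyethyl, with no ring and one hydrogen-bond acceptor. Losing the aromatic ring for this open chain gives a 1.2-fold lower number from compound 2 to compound 4 (0.09 log units; within the scatter) and so leaves compound 4 indistinguishable from compound 2, which means that an aromatic ring is not needed here for a number of this size. Within the open chains, the comparison with butyl gives a 1.2-fold higher number from compound 1 to compound 4 (0.07 log units; within the scatter) and shows that an oxygen in the chain also leaves the number indistinguishable, although no measurement here explains why these groups read alike.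

Going by these compounds, whether a group carrying an amine or a carboxylic acid at this place, or a much longer chain, would move the number beyond the scatter remains open. All of these compounds also keep the oxygen next to the carbonyl group, so what an amide nitrogen in its place would give is unknown as well.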